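Bromo Replaces tert-Butyl on a Shared Benzoxazole-Free Core

The compounds below may be only part of what the source reports. "The series", "measured", "known", "first", "only" and "open" are said of these compounds alone.

Three compounds on the shared core have been examined in a functional assay on ileum (strain Hartley) for agonist activity at 5-hydroxytryptamine receptor 3A (Cavia porcellus); on this read-out lower numbers stand for lower potency and higher numbers for higher potency (the scale is a negative logarithm). Compound 1 `CN1CCN(c2nc3cc(C(F)(F)F)ccc3o2)CC1` carries a trifluoromethyl group; in this assay compound 1 reaches only a limit of the assay, < 4. Compound 2 `CN1CCN(c2nc3cc(F)ccc3o2)CC1` carries fluoro in that place and in this assay compound 2 gives 5.57. Compound 3 `CN1CCN(c2nc3cc(C(C)(C)C)ccc3o2)CC1` carries tert-butyl; in this assay compound 3 also sits at a limit of the assay, < 4. Thus compound 3 stands at the floor of the numbers shown, because of the limit of < 4 in this assay, at which 2 of the 3 values shown sit. The step from fluoro to tert-butyl is a number at least 1.57 log units lower from compound 2 to compound 3 (beyond the scatter), the step from trifluoromethyl to fluoro is a number at least 1.57 log units higher from compound 1 to compound 2 (beyond the scatter), and the step from trifluoromethyl to tert-butyl is a step that the two limits leave unreadable from compound 1 to compound 3.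

Compound 4 `CN1CCN(c2nc3cc(Br)ccc3o2)CC1` is not yet measured. It differs from compound 3 by bromo in place of tert-butyl on an aromatic carbon. The bromo group of compound 4 is a halogen like the fluoro of compound 2, and the large step of a number at least 1.57 log units lower from compound 2 to compound 3 (beyond the scatter) suggests that removing tert-butyl may recover part of that loss, so a gain is expected, a number at least 0.80 log units higher from compound 3 to compound 4 (beyond the scatter), though compound 4 may itself sit at a limit. The estimate for compound 4 is 4.8, between 4 and 5.6.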

Compound 4, negative logarithm of the half-maximal effective concentration: 6.21
Compound 4: the middle estimate sits 1.41 log units below what was measured, and the stated range ends below it.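

In this assay, compound 4 shows that the loss seen with tert-butyl on this aromatic carbon does not extend to every group that replaces fluoro: the change to bromo is a number at least 2.21 log units higher from compound 3 to compound 4 (beyond the scatter), and the change from trifluoromethyl to bromo is a number at least 2.21 log units higher from compound 1 to compound 4 (beyond the scatter). Bromo also goes past fluoro, with a number 0.64 log units higher from compound 2 to compound 4 (beyond the scatter), so fluoro no longer marks the top of the series, and among these four compounds only the two halogens give readable numbers, while trifluoromethyl and tert-butyl do not. The two large steps are lower bounds rather than sizes, because compound 1 and compound 3 both sit at a limit of the assay: the limit of < 4 in this assay, at which 2 of the 4 values shown sit.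

The compounds shown leave open whether the gain from fluoro to bromo would continue with iodo or would place chloro between the two, and whether this position tolerates anything other than a halogen, such as an amine, a methoxy group or a nitrile. They also leave open how far compound 1 and compound 3 lie beneath their limit, and so how large the true gain to bromo is.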